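Acylsulfonamide antagonists: a pyridyl for a methoxyphenyl

This account rests on a few compounds, and the source may have more. Where it says the series, first, only, none or still open, it means among the compounds named here.

Of the compounds shown here, three have been measured in a functional assay (trachea) for antagonist activity, with Cavia porcellus as the target; a lower number here means a less potent compound, a higher number a more potent compound, by a factor of ten per unit of this negative logarithm. Compound 1 `COc1cc(C(=O)NS(=O)(=O)c2ccccc2OC)ccc1Cn1ccc2ccc(NC(=O)CC3CCCC3)cc21` gives 9.7 and stands highest of the three. Compound 2 `CCCCOC(=O)Nc1ccc2cnn(Cc3ccc(-c4nn[nH]n4)cc3OC)c2c1` gives 7.1, and compound 3 `CCCCOC(=O)Nc1ccc2ccn(Cc3ccc(-c4nn[nH]n4)cc3OC)c2c1` gives 7.2. The gap between compound 1 and compound 3 is beyond the scatter. The gap between compound 1 and compound 2 is beyond the scatter as well, and compound 1 is the most potent of the three. Going by the values given here, compounds 2 and 3 share a different arrangement of the core and a tetrazole in place of the acylsulfonamide, and no single-point step between any two measured compounds is available, so nothing about the acylsulfonamide portion itself has been tested yet.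

Compound 4 `COc1cc(C(=O)NS(=O)(=O)c2ccccn2)ccc1Cn1ccc2ccc(NC(=O)CC3CCCC3)cc21` differs from compound 1 only at the sulfonyl sulfur: pyridin-2-yl in place of 2-methoxyphenyl on a sulfonyl sulfur. The rest of the molecule, including the amide-type nitrogen and the cyclopentyl acetamide, is unchanged. Among the compounds with values here, with no measured pair to lean on, the size of the step in this assay is an open question; a change within the scatter or a modest decrease seems most plausible, and the step is estimated as a number 0.40 log units lower from compound 1 to compound 4 (beyond the scatter). Compound 4 is accordingly expected to give about 9.3, most likely between 8.6 and 10.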

Compound 4, negative logarithm of the antagonist equilibrium constant: 8.9
Beside the measured number, compound 4's estimate is 0.40 log units above it; the range from low to high includes it.
By their numbers in this assay, from the lowest: compounds 2 and 3 (each within the scatter of the next); then compound 4; then compound 1.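

In this assay, going by these compounds alone, the exchange on the sulfonyl sulfur gives the first single-point step, a number 0.80 log units lower from compound 1 to compound 4 (beyond the scatter), which shows that the read-out responds to the group at this position. The change from 2-methoxyphenyl to pyridin-2-yl costs potency without removing it, as compound 4 still gives 8.9 with the rest of the molecule unchanged. Within the data shown here, nothing available here explains the drop, and the single step does not divide it between the departure of the methoxy group and the arrival of the ring nitrogen.

Open, then, is which of those two differences carries the step: an unsubstituted phenyl on the sulfonyl sulfur would stand apart from both compound 1 and compound 4 by only one of them, and a pyridin-3-yl would show whether the place of the ring nitrogen matters. Also open, as far as these compounds go, is how much of the potency depends on the acylsulfonamide itself, which a carboxylic acid on the otherwise unchanged core of compound 1 would test directly.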